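The source may hold more compounds than are shown below. What is called first, only, known or untested is meant among the compounds shown, and "the series" means these compounds.

Compound 3 `CC(C1=C(CCCN(C)C)Cc2ccccc21)c1ccccn1` belongs to a set of three compounds with a shared core tested in an assay on CHO-K1 cells for binding affinity to muscarinic acetylcholine receptor M5 (Homo sapiens); on this read-out higher numbers stand for weaker inhibition and lower numbers for stronger inhibition; compound 3 gives 3240 nM. Compound 1 `CC(C1=C(CCN2CCCCC2)Cc2ccccc21)c1ccccn1` gives 2340 nM, and compound 2 `CC(C1=C(CCN2CCCC2)Cc2ccccc21)c1ccccn1` gives 2000 nM. For the measured compounds named here, the three differ only in the group on a saturated chain carbon, two bonds along the chain from a double-bonded ring carbon, and the steps between them read a 1.2-fold lower number from compound 1 to compound 2 (0.07 log units; within the scatter), a 1.4-fold higher number from compound 1 to compound 3 (0.14 log units; within the scatter) and a 1.6-fold higher number from compound 2 to compound 3 (0.21 log units; within the scatter), so no compound stands apart from the others. Compound 4 `CC(C1=C(CN(C)C(C)C)Cc2ccccc21)c1ccccn1` is not yet measured; it carries the same atoms as compound 3, joined differently: isopropyl(methyl)amino in place of 2-(dimethylamino)ethyl on a saturated chain carbon bound to a double-bonded ring carbon. The known steps all exchanged one such group for another and stayed small, which points to a similarly small change, though none of them rearranged the chain itself, so the range is kept wide. Compound 4 is expected to give 4000 nM in this assay, between 1500 nM and 12000 nM. The expected step is a 1.2-fold higher number from compound 3 to compound 4 (0.09 log units; within the scatter).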

Compound 4, inhibition constant: 1120 nM
Compound 4: middle estimate off by 3.6-fold (0.55 log units), on the high side; measured number below the stated range.
By their numbers in this assay, from the lowest: compounds 4, 2, 1 and 3 (each within the scatter of the next, the first and the last beyond it).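

Joining the same atoms differently, as isopropyl(methyl)amino in place of 2-(dimethylamino)ethyl, gives the first step in this assay to pass the scatter at this position (a 2.9-fold lower number from compound 3 to compound 4 (0.46 log units; beyond the scatter)), while the earlier exchanges all stayed within it. Compound 4 also passes the scatter against compound 1 (a 2.1-fold lower number from compound 1 to compound 4 (0.32 log units; beyond the scatter)) but not against compound 2 (a 1.8-fold lower number from compound 2 to compound 4 (0.25 log units; within the scatter)), so it does not stand clear of the whole set. Nothing available explains this shift. The compounds shown leave open whether the shorter chain or the branched isopropyl group matters, since the change from compound 3 to compound 4 alters both at once. On these data alone, how a morpholin-4-yl group would read at this position also remains open.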